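Chloro in Place of Trifluoromethyl in Two Compound Pairs

The source may report more compounds than this note shows. Statements on the series, on what has been measured and on what is new or still open speak of the compounds shown alone.

Measured in a functional assay on PBMC cells (Homo sapiens) for inhibition, read by HTRF, with stated times of 15 min and 24 h; on this read-out higher numbers stand for weaker inhibition and lower numbers for stronger inhibition:
- compound 1 `O=C(Nc1ccc2c(c1)B(O)OC2)c1ccccc1C(F)(F)F` gives 2100 nM.
- compound 2 `O=C(Nc1ccc2c(c1)B(O)OC2)c1ccccc1Cl` reaches only a limit of the assay, > 100000 nM.
- compound 3 `O=C(Nc1ccc2c(c1)B(O)OC2)c1cccc(C(F)(F)F)c1F` also reaches only a limit of the assay, > 100000 nM.

The change from compound 1 to compound 2 is chloro in place of trifluoromethyl on an aromatic carbon. It gave an at least 47-fold higher number from compound 1 to compound 2 (1.67 log units; beyond the scatter), and compound 2 sits at the limit of > 100000 nM in this assay, at which 2 of the 3 values shown sit. The difference between the cores of compound 1 and compound 3 is not broken down here.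

Compound 4 `O=C(Nc1ccc2c(c1)B(O)OC2)c1cccc(Cl)c1F` differs from compound 3 by chloro in place of trifluoromethyl on an aromatic carbon. The surroundings differ: in compound 1 the place is ortho to a large group, in compound 3 ortho to a fluoro group (1 heavy atom) and meta to a large group, so this is the same kind of change, not the same change. Since compound 3 already stands at the limit of > 100000 nM in this assay, at which 2 of the 3 values shown sit, and the earlier step weakened inhibition by an at least 47-fold higher number from compound 1 to compound 2 (1.67 log units; beyond the scatter), compound 4 is expected to stay at that limit, a step that the limit leaves unreadable from compound 3 to compound 4. Compound 4 is therefore estimated at 200000 nM in this assay, with an expected range from 100000 nM to 1000000 nM.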

Compound 4, half-maximal inhibitory concentration: > 100000 nM
Compound 4 ended at the assay's limit (the forecaster's own chance of this, stated with the estimate: 90%); the middle value lies beyond the limit too.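

No step can be read from compound 3 to compound 4, since both stop at the same assay limit: the limit of > 100000 nM in this assay, at which 3 of the 4 values shown sit.

As far as these compounds go, whether chloro in place of trifluoromethyl changes inhibition in this surrounding, with the fluoro group present, stays open.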